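Alkynyl series: chlorophenyl swap on the isopropyl amide core

This account rests on a few compounds, and the source may have more. Where it says the series, first, only, none or still open, it means among the compounds named here.

Measured compounds:
compound 1 `Cc1ccccc1C#Cc1ccc2c(n1)CCN(C)C2=O`, 776 nM
compound 2 `CN1CCc2nc(C#Cc3cccc(Cl)c3)ccc2C1=O`, 22 nM
compound 3 `Cc1ccccc1C#Cc1ccc2c(n1)CCN(C(C)C)C2=O`, 810 nM

Compound 3 stands highest of the three numbers in a functional assay on HEK293 cells for negative allosteric modulation of metabotropic glutamate receptor 5 (Homo sapiens), read by FLIPR and calcium flux (a lower number here means a stronger inhibitor, a higher number a weaker inhibitor), though its gap to compound 1 lies within the scatter; compound 2 sits far below both. Compound 4 `CC(C)N1CCc2nc(C#Cc3ccc(Cl)cc3)ccc2C1=O` is the next step from compound 3: 4-chlorophenyl in place of 2-methylphenyl on a triple-bonded carbon. Among the measured compounds shown here, the one measured step that bears directly on this change is the chlorophenyl swap on the methyl core, a 35-fold lower number from compound 1 to compound 2 (1.55 log units; beyond the scatter), which was large; the chlorine there, however, sits as 3-chlorophenyl, not 4-chlorophenyl, so the size carries over only in part. The core change itself, a 1.0-fold higher number from compound 1 to compound 3 (0.02 log units; within the scatter), was within the scatter, so the isopropyl core is taken to respond like the methyl core. A clearly lower number is therefore expected for compound 4, with the uncertainty of the untested chlorine placement: the estimated step is a 12-fold lower number from compound 3 to compound 4 (1.06 log units; beyond the scatter), and compound 4 is expected at about 70 nM in this assay, within 15 nM to 350 nM.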

Compound 4, half-maximal inhibitory concentration: 4230 nM
The estimate for compound 4 lay 60-fold (1.78 log units) below the measured number, outside the stated range (above it).
By their numbers in this assay, from the lowest: compound 2; then compounds 1 and 3 (each within the scatter of the next); then compound 4.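

On the triple-bonded carbon of the isopropyl compound, 4-chlorophenyl in place of 2-methylphenyl gives a 5.2-fold higher number from compound 3 to compound 4 (0.72 log units; beyond the scatter) in this assay and so runs opposite to the swap to 3-chlorophenyl on the methyl compound, which gave a 35-fold lower number from compound 1 to compound 2 (1.55 log units; beyond the scatter) in the same assay. A chlorophenyl group at this carbon therefore does not lower the number in every case, and the two steps differ in both the chlorine placement and the substituent on the amide-type nitrogen. Nothing at hand explains the higher number of compound 4.

Still open, going by these compounds, is which of those two differences sets the direction, which 3-chlorophenyl on the isopropyl core or 4-chlorophenyl on the methyl core would settle. Also open, on these data alone, is how a 2-chlorophenyl or 3-methoxyphenyl group would read at this carbon.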